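From Diethylamino to Morpholin-4-yl on the Thiocarbonyl Carbon

A few compounds are considered here, and "the series" means these few. Any claim that something is new, unique, unknown or untested is made for them only; others in the source may bear on it.

Going by the values given here, compound 2 `CCN(CC)C(=S)SCc1cc(=O)c2ccc(Cl)cc2o1` gives 8800 nM in a functional assay on HEp-2 cells (Homo sapiens) for antiproliferative activity, read by MTT assay, with a stated time of 72 h (on this read-out higher numbers stand for weaker inhibition and lower numbers for stronger inhibition), the only number among the two values shown. Compound 1 `O=c1cc(CSC(=S)N2CCCC2)oc2cc(Cl)ccc12` gives > 40000 nM in this assay, which is a limit rather than a number (the limit of > 40000 nM in this assay, at which 1 of the 2 values shown sits). Among the compounds with values here, the only measured step bearing on the change is an at least 4.5-fold lower number from compound 1 to compound 2 (0.65 log units; beyond the scatter), where a cyclic amine gave way to an open one. Compound 3 `O=c1cc(CSC(=S)N2CCOCC2)oc2cc(Cl)ccc12` differs from compound 2 by morpholin-4-yl in place of diethylamino on a thiocarbonyl carbon, returning to a cyclic amine. Compound 3 is therefore expected to show weaker inhibition, with an estimated 25000 nM (range 8000 nM to 60000 nM). The expected step is a 2.8-fold higher number from compound 2 to compound 3 (0.45 log units; beyond the scatter).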

Compound 3, half-maximal inhibitory concentration: 20600 nM
Beside the measured number, compound 3's estimate is 1.2-fold (0.08 log units) above it; low and high end bracket the measured number.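

Morpholin-4-yl in place of diethylamino brings a 2.3-fold higher number from compound 2 to compound 3 (0.37 log units; beyond the scatter), so the open amine keeps the lower number, while this ring, unlike pyrrolidin-1-yl, gives a measured value. Against pyrrolidin-1-yl, morpholin-4-yl gives an at least 1.9-fold lower number from compound 1 to compound 3 (0.28 log units; that floor lies within the scatter), so the two rings cannot be firmly ordered. The entry for compound 1 is a limit and not a number: the limit of > 40000 nM in this assay, at which 1 of the 3 values shown sits.

As far as these compounds go, whether piperidin-1-yl would behave like the other rings remains open. So does whether a longer open chain, such as dipropylamino, would lower the number further than diethylamino.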